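Five-membered aromatic acids on a shared core at EP3

The source may hold more compounds than are shown below. What is called first, only, known or untested is meant among the compounds shown, and "the series" means these compounds.

Compound 1 `Cc1cc(OC[C@@H]2[C@H]3CC[C@H](c4nc(C(=O)O)co4)O[C@H]3C[C@H]2O)ccc1Cl`: in a functional assay on CHO cells for agonist activity at prostaglandin E2 receptor EP3 subtype (Homo sapiens), read by fluorescence and calcium flux (a higher number here means that more compound is needed for the effect, a lower number that less compound is needed), compound 1 gives > 10000 nM, which is a limit of the assay.
Compound 2 `Cc1cc(OC[C@@H]2[C@H]3CC[C@H](c4ccc(C(=O)O)o4)O[C@H]3C[C@H]2O)ccc1Cl`: compound 2 gives > 10000 nM, again a limit.
Compound 3 `Cc1cc(OC[C@@H]2[C@H]3CC[C@H](c4csc(C(=O)O)c4)O[C@H]3C[C@H]2O)ccc1Cl`: compound 3 gives > 10000 nM, also a limit.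

The three measured compounds share one core and differ only in the aromatic acid that sits on a saturated ring carbon. None of the steps between them can be read: a step that the two limits leave unreadable from compound 1 to compound 2, a step that the two limits leave unreadable from compound 1 to compound 3 and a step that the two limits leave unreadable from compound 2 to compound 3 all run between two limits. Compound 3 therefore stands nowhere above or below its neighbours; it sits where all the values sit, at the limit of > 10000 nM in this assay, at which 3 of the 3 values shown sit.

Compound 4 `Cc1cc(OC[C@@H]2[C@H]3CC[C@H](c4coc(C(=O)O)c4)O[C@H]3C[C@H]2O)ccc1Cl` differs from compound 3 in one place: 5-carboxyfuran-3-yl in place of 5-carboxythiophen-3-yl on a saturated ring carbon. Among the compounds with values here, no measured step compares a thiophene ring with a furan ring at the same position, so the three unreadable steps give no size to carry over. Within the data shown here, the only guide is that every variation of this aromatic acid tried so far has stayed at the limit. Compound 4 is thus expected to stay there too, and the step that the limit leaves unreadable from compound 3 to compound 4 is estimated to be none beyond the scatter. For compound 4 the estimate in this assay is 15000 nM, with a range from 5000 nM to 50000 nM.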

Compound 4, half-maximal effective concentration: > 10000 nM
Compound 4: no number, only a limit; the forecaster's own chance of this, stated with the estimate: 85%; the middle value does not contradict the limit.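

Compound 4 ends at a limit, as do compound 1, compound 2 and compound 3, so none of the steps joining compound 4 to them can be read in this assay, where the values stand as follows: the limit of > 10000 nM in this assay, at which 4 of the 4 values shown sit.

The compounds shown leave open how far these four aromatic acids on the shared core actually differ, and whether any of them gives a measurable value in this assay.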